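Branching the Chain: From Hexyl to 3,3-Dimethylbutyl

The source may report more compounds than this note shows. Statements on the series, on what has been measured and on what is new or still open speak of the compounds shown alone.

Compound 1 `CC(C)(C)CCNc1ccc([N+](=O)[O-])cc1S(N)(=O)=O`: 14.5%
Compound 2 `CCCCNc1ccc([N+](=O)[O-])cc1S(=O)(=O)N(C)C`: 15.2%
Compound 3 `CCCCCCNc1ccc([N+](=O)[O-])cc1S(=O)(=O)N(C)C`: 4.9%

In an assay on HEK293 cells for inhibition of solute carrier family 12 member 2 (Homo sapiens), read by fluorescence, with a stated time of 30 min, tested at 100 uM (on this read-out lower numbers stand for a weaker effect and higher numbers for a stronger effect at the one concentration tested), compound 3 gives the lowest of the three numbers; compound 1 lies within the scatter of it, while compound 2 sits beyond the scatter above it. Compound 4 `CN(C)S(=O)(=O)c1cc([N+](=O)[O-])ccc1NCCC(C)(C)C` differs from compound 3 by tert-butyl in place of butyl on a saturated chain carbon, two bonds along the chain from a nitrogen on an aromatic ring. Within the data shown here, the only measured step, a number 10.3 percentage points lower from compound 2 to compound 3 (beyond the scatter), moved the number down modestly as the chain grew; no step covers the move from hexyl to 3,3-dimethylbutyl. Compound 1, which carries the same (3,3-dimethylbutyl)amino chain on a different core, gives a number within the scatter of compound 3. Compound 4 is therefore expected to give 10%, between 0% and 22%, an expected step of a number 5.1 percentage points higher from compound 3 to compound 4 (within the scatter) that stays within the scatter.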

Compound 4, a percentage reported as inhibition, at one concentration (the size of the read-out at that concentration, not a potency): 17%
Estimate against measurement, compound 4: 7 percentage points below; the measured number falls inside the stated range.
By their numbers in this assay, from the lowest: compounds 3, 1, 2 and 4 (each within the scatter of the next, the first and the last beyond it).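

In this assay the same carbons, rearranged from hexyl to 3,3-dimethylbutyl, give a number 12.1 percentage points higher from compound 3 to compound 4 (beyond the scatter) at this place, so the shape of the chain counts here and not only its carbons. The branched chain gives a number 1.8 percentage points higher from compound 2 to compound 4 (within the scatter) against butyl, and dimethylamino in place of amino on the sulfonyl sulfur gives a number 2.5 percentage points higher from compound 1 to compound 4 (within the scatter) with the chain unchanged. Nothing measured here explains why branching changes the number.

Open, going by these compounds, is how a longer chain such as octyl, or a chain ending in a carboxylic acid or an amine, would read at this place. These numbers are also readings at one concentration, so they say nothing about potency.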